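Swapping Dichlorophenyl for Cyanophenyl on a Shared Core

The compounds below may be only part of what the source reports. "The series", "measured", "known", "first", "only" and "open" are said of these compounds alone.

Of the compounds shown here, three have been tested in a functional assay on HEK293 cells for agonist activity at G-protein coupled receptor 39 (Homo sapiens), read by scintillation proximity assay and inositol phosphate accumulation, with a stated time of 75 min, in the presence of a further agent that is not named here; a higher number here means that more compound is needed for the effect, a lower number that less compound is needed. Compound 1 `Cc1nn(-c2ncnc3nc[nH]c23)c2c1C(OCc1ccccc1Cl)CC(=O)N2` gives 2 nM, compound 2 `C=CCN1c2c(n(C)c(=O)n(C)c2=O)NC1N/N=C/c1ccc(O)cc1O` gives 340 nM, and compound 3 `Cc1nn(-c2ncnc3nc[nH]c23)c2c1C(OCc1ccc(Cl)cc1Cl)CC(=O)N2` gives 4 nM. Compound 3 thus holds the second highest of the three numbers: its nearest neighbour is compound 1, separated by a step within the scatter, while compound 2 lies far above it, beyond the scatter. Compound 4 `Cc1nn(-c2ncnc3nc[nH]c23)c2c1C(OCc1ccccc1C#N)CC(=O)N2` differs from compound 3 in one place: 2-cyanophenyl in place of 2,4-dichlorophenyl on a saturated chain carbon bound to an oxygen on a saturated carbon. Among the compounds with values here, the one measured step that bears on this, a 2.0-fold higher number from compound 1 to compound 3 (0.30 log units; within the scatter), shows that chloro in place of hydrogen on an aromatic carbon moved the number only within the scatter; nothing measured speaks to the nitrile. The step expected here is a 1.3-fold lower number from compound 3 to compound 4 (0.12 log units; within the scatter), within the scatter. Compound 4 is estimated at 3 nM, between 1 nM and 12 nM.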

Compound 4, half-maximal effective concentration: 8 nM
Estimate against measurement, compound 4: 2.7-fold (0.43 log units) below; measured number inside the range.
By their numbers in this assay, from the lowest: compounds 1, 3 and 4 (each within the scatter of the next, the first and the last beyond it); then compound 2.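

Replacing 2,4-dichlorophenyl with 2-cyanophenyl gives a 2.0-fold higher number from compound 3 to compound 4 (0.30 log units; within the scatter) in this assay, so at this position the nitrile-bearing ring does not separate from the dichlorinated one. Cyano in place of chloro on the aromatic carbon gives a 4.0-fold higher number from compound 1 to compound 4 (0.60 log units; beyond the scatter), the first step on this ring to pass the scatter, though only modestly. No measurement at hand offers a reason for either step. Still open, going by these compounds, is whether a methoxy group or an amine in place of the nitrile would keep the number this low, and whether a longer chain would be tolerated at this place.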